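Adding a Second Trifluoromethyl to Compound 2

The source may hold more compounds than are shown below. What is called first, only, known or untested is meant among the compounds shown, and "the series" means these compounds.

Of the compounds shown here, three built on one shared core have been tested in a functional assay on PC-3 cells (Homo sapiens) for cytotoxicity, read by MTT assay, with a stated time of 72 h; on this read-out higher numbers stand for weaker inhibition and lower numbers for stronger inhibition. Compound 1 `CC1=C(/C=C/C(=O)/C=C/c2ccccc2)C(C)(C)CCC1O` gives 15500 nM. Compound 2 `CC1=C(/C=C/C(=O)/C=C/c2cccc(C(F)(F)F)c2)C(C)(C)CCC1O` gives 3500 nM, the second highest of the three numbers. Compound 3 `CC1=C(/C=C/C(=O)/C=C/c2cc(C(F)(F)F)ccc2C(F)(F)F)C(C)(C)CCC1O` gives 1900 nM. Compound 4 `CC1=C(/C=C/C(=O)/C=C/c2cc(C(F)(F)F)cc(C(F)(F)F)c2)C(C)(C)CCC1O` is not yet measured; it differs from compound 2 by trifluoromethyl in place of hydrogen on an aromatic carbon. Two measured steps of the same kind are known: a 4.4-fold lower number from compound 1 to compound 2 (0.65 log units; beyond the scatter) and a 1.8-fold lower number from compound 2 to compound 3 (0.27 log units; within the scatter). A modest gain is therefore expected in this assay, and the expected step is a 1.8-fold lower number from compound 2 to compound 4 (0.24 log units; within the scatter), kept smaller than the first step because a 1.8-fold lower number from compound 2 to compound 3 (0.27 log units; within the scatter) was already small. Compound 4 is thus estimated at 2000 nM, with a range from 900 nM to 4500 nM.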

Compound 4, half-maximal inhibitory concentration: 7000 nM
The estimate for compound 4 lay 3.5-fold (0.54 log units) below the measured number; the measured number lies above the stated range.
By their numbers in this assay, from the lowest: compounds 3, 2 and 4 (each within the scatter of the next, the first and the last beyond it); then compound 1.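

In this assay, a second trifluoromethyl placed meta to a trifluoromethyl group gives a 2.0-fold higher number from compound 2 to compound 4 (0.30 log units; within the scatter), so the clear gain seen with the first trifluoromethyl is not repeated at this position. On this carbon, the added group has no effect that can be told apart from the ordinary scatter of repeated measurements. No measurement shown here explains this result.

Still open, going by these compounds, is whether a smaller group on this carbon, such as a fluorine atom or a nitrile, would move the number beyond the scatter. An amine or a carboxylic acid here is equally untested by the compounds shown.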